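This account rests on a few compounds, and the source may have more. Where it says the series, first, only, none or still open, it means among the compounds named here.

Measured so far:
compound 1 `S=C(NCc1ccccc1)N/N=C/c1ccc2ccccc2n1`: 62800 nM
compound 2 `CN(C)C(=S)N/N=C/c1cnc2ccccc2n1`: 750 nM

In a functional assay on HeLa cells (Homo sapiens) for antiproliferative activity, read by sulforhodamine B assay, with a stated time of 72 h (a higher number here means a weaker inhibitor, a lower number a stronger inhibitor), compound 1 gives 62800 nM, the highest of the two numbers. Going by the values given here, compound 2 gives 750 nM in this assay, a gap beyond the scatter, but the two compounds differ at more than one place and no single step joins them. Compound 3 `Fc1ccc(NC(=S)N/N=C/c2ccc3ccccc3n2)cc1` is not yet measured. It differs from compound 1 by one change: 4-fluorophenyl in place of benzyl on an amide-type nitrogen. A modest step toward a lower number is expected, estimated as a 3.1-fold lower number from compound 1 to compound 3 (0.50 log units; beyond the scatter). Compound 3 is thus expected to give about 20000 nM in this assay, within a range of 5000 nM to 80000 nM.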

Compound 3, half-maximal inhibitory concentration: 33200 nM
Beside the measured number, compound 3's estimate is 1.7-fold (0.22 log units) below it, and the stated range covers the measured number.
By their numbers in this assay, from the lowest: compound 2; then compounds 3 and 1 (each within the scatter of the next).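

In this assay, 4-fluorophenyl in place of benzyl on the amide-type nitrogen gives a 1.9-fold lower number from compound 1 to compound 3 (0.28 log units; within the scatter), the first single-place step read at this position. On this evidence, the two groups are not told apart on the core of compound 1. No available evidence bears on this result.
Still open, as far as these compounds go, is how plain phenyl, a longer chain such as phenethyl or a phenyl ring carrying a carboxylic acid would read at this nitrogen. Whether a change at this position reaches beyond the scatter on this core also remains unsettled.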